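Sulfonyl aryl exchange in the piperidine carboxamide series

The source may report more compounds than this note shows. Statements on the series, on what has been measured and on what is new or still open speak of the compounds shown alone.

Compound 2 `CCN(C(=O)C1CCN(S(=O)(=O)c2ccc3c(c2)CCO3)CC1)[C@H](C)c1ccccc1` gives 88% in a functional assay on CHO cells for positive allosteric modulation of muscarinic acetylcholine receptor M5 (Homo sapiens), read by calcium flux (on this read-out higher numbers stand for larger maximal responses and lower numbers for smaller maximal responses), and stands highest of the two numbers measured. Compound 1 `CCN(Cc1ccccc1)C(=O)C1CCN(S(=O)(=O)c2cccc(OC)c2)CC1` gives 77% in this assay, a value lower than that of compound 2 by more than the usual scatter. Compound 3 `CCN(C(=O)C1CCN(S(=O)(=O)c2ccc3[nH]ncc3c2)CC1)[C@H](C)c1ccccc1` has not been measured. It differs from compound 2 by a group of 9 heavy atoms (7 carbon, 2 nitrogen; one five-membered aromatic ring with 2 hetero atoms, one six-membered aromatic ring of carbon only) in place of a group of 9 heavy atoms (8 carbon, 1 oxygen; one five-membered non-aromatic ring with 1 hetero atom, one six-membered aromatic ring of carbon only), on a sulfonyl sulfur. Within the data shown here, no measured pair bears on this exchange. The step is therefore expected to stay within the scatter, estimated as a number 3 percentage points lower from compound 2 to compound 3 (within the scatter). Compound 3 is expected to give 85%, with a range from 65% to 105%.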

Compound 3, largest response reached (reported as percent of maximum), in percent of the reference or control that the assay uses: 86%
Beside the measured number, compound 3's estimate is 1 percentage points below it; low and high end bracket the measured number.
By their numbers in this assay, from the lowest: compounds 1, 3 and 2 (each within the scatter of the next, the first and the last beyond it).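

In this assay, placing 1H-indazol-5-yl on the sulfonyl sulfur amounts to a number 2 percentage points lower from compound 2 to compound 3 (within the scatter). At this position, a group with 1 hydrogen-bond donor and a five-membered aromatic ring with 2 hetero atoms therefore matches the group with no donor and a non-aromatic oxygen ring in compound 2 on this read-out. Nothing available gives a reason for this outcome. Open, going by these compounds, is whether the hydrogen on the indazole nitrogen matters, which an N-methyl indazole would test. On these data alone, a phenyl group carrying a carboxylic acid or an amine on the sulfonyl sulfur also remains open.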